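The source may hold more compounds than are shown below. What is called first, only, known or untested is meant among the compounds shown, and "the series" means these compounds.

Compound 1 `O=C(O)Cc1sc(C(c2ccccc2)c2ccccc2)nc1-c1ccccc1` gives 570 nM in an in vitro assay on HEK385-7 cells for displacement of a labelled ligand from prostaglandin D2 receptor 2 (Homo sapiens); on this read-out higher numbers stand for weaker inhibition and lower numbers for stronger inhibition. For the measured compounds named here, compound 3 `O=C(O)Cc1sc(C(c2ccccc2)c2ccccc2)nc1-c1ccc(F)c(F)c1` gives 4.1 nM in this assay, and the one change between them, a 140-fold lower number from compound 1 to compound 3 (2.14 log units; beyond the scatter), shows that the group at this place on the shared core can shift the number a great deal. Compound 2 `O=C(O)Cc1sc(C(c2ccc(F)cc2)c2ccc(F)cc2)nc1-c1ccnc(N2CCCC2)c1` gives 230 nM in this assay, a number below that of compound 1 and far above that of compound 3. Compound 4 `O=C(O)Cc1sc(C(c2ccc(F)cc2)c2ccc(F)cc2)nc1-c1cn[nH]c1` differs from compound 2 by 1H-pyrazol-4-yl in place of 2-(pyrrolidin-1-yl)pyridin-4-yl on an aromatic carbon. Going by the values given here, the only measured step touching this place was large, yet it swapped one six-membered ring for another, so the direction for a smaller five-membered ring is uncertain. Compound 4 is expected to give about 500 nM, between 80 nM and 3000 nM, an estimated step of a 2.2-fold higher number from compound 2 to compound 4 (0.34 log units; beyond the scatter).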

Compound 4, half-maximal inhibitory concentration: 16 nM
Beside the measured number, compound 4's estimate is 31-fold (1.49 log units) above it; measured number outside the range, below it.
By their numbers in this assay, from the lowest: compound 3; then compound 4; then compound 2; then compound 1.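

The step of a 14-fold lower number from compound 2 to compound 4 (1.16 log units; beyond the scatter) shows that this place does not need a six-membered ring for a low number: the smaller 1H-pyrazol-4-yl, which carries a hydrogen-bond donor, does far better than 2-(pyrrolidin-1-yl)pyridin-4-yl. This place now gives a large step with a second pair of compounds, which carries a different large group on the shared core. The compounds shown leave open whether the hydrogen on the pyrazole nitrogen matters, which a methyl group on that nitrogen or an isoxazole ring would test. Nothing available explains why the number falls.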